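Aryl change on the styryl arm of compound 2

The source may hold more compounds than are shown below. What is called first, only, known or untested is meant among the compounds shown, and "the series" means these compounds.

Compound 1 `COC(=O)/C=C/c1cccc(N(Cc2ccc(/C=C/c3cc(C(F)(F)F)cc(C(F)(F)F)c3)cc2)C(=O)C(C)C)c1`, compound 2 `COC(=O)/C=C/c1cccc(N(Cc2ccc(/C=C/c3cccc(C(F)(F)F)c3)cc2)C(=O)C(C)C)c1` and compound 3 `COC(=O)/C=C/c1cccc(N(Cc2ccc(/C=C/c3cccc(C(F)(F)F)c3)cc2)C(=O)NC(C)C)c1` share one core and were characterised in an assay on isolated protein with Bile acid receptor (Homo sapiens) as the target; on this read-out higher numbers stand for an effect only at larger amounts of compound and lower numbers for an effect already at smaller amounts. In this assay compound 1 gives 1950 nM, compound 2 gives 267 nM and compound 3 gives 932 nM. Compound 2 thus holds the lowest number of the three; its nearest neighbour is compound 3 and its furthest is compound 1. The step of a 7.3-fold lower number from compound 1 to compound 2 (0.86 log units; beyond the scatter) is the only one that touches the aryl ring at the end of the double-bonded chain; the step of a 3.5-fold higher number from compound 2 to compound 3 (0.54 log units; beyond the scatter) sits on the carbonyl carbon and does not bear on the present change. Compound 4 `COC(=O)/C=C/c1cccc(N(Cc2ccc(/C=C/c3c(C)cc(C)cc3C)cc2)C(=O)C(C)C)c1` differs from compound 2 in that (2,4,6-trimethylphenyl in place of 3-(trifluoromethyl)phenyl on a double-bonded chain carbon bound to a double-bonded chain carbon). For the measured compounds named here, the one relevant step shows that the aryl substitution pattern moves this assay by a modest amount, and the new ring has no measured precedent. A modest rise in number, a 2.6-fold higher number from compound 2 to compound 4 (0.42 log units; beyond the scatter), is therefore expected for compound 4, with wide uncertainty. Compound 4 is estimated at 700 nM, within 200 nM to 2500 nM.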

Compound 4, half-maximal effective concentration: 149 nM
Beside the measured number, compound 4's estimate is 4.7-fold (0.67 log units) above it, and the stated range ends above it.
By their numbers in this assay, from the lowest: compounds 4 and 2 (each within the scatter of the next); then compound 3; then compound 1.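

In this assay, the step at the double-bonded chain carbon is a 1.8-fold lower number from compound 2 to compound 4 (0.25 log units; within the scatter), so 2,4,6-trimethylphenyl and 3-(trifluoromethyl)phenyl are not separated at this position, and a trifluoromethyl group is not required there for a number in this range. The earlier change at the same ring, a 7.3-fold lower number from compound 1 to compound 2 (0.86 log units; beyond the scatter), had suggested that added substitution on this ring raises the number, but compound 4, with its three methyl groups, does not follow that reading. No measurement shown accounts for either step.

Going by these compounds, it remains open whether a 3.5-fold higher number from compound 2 to compound 3 (0.54 log units; beyond the scatter), seen with 3-(trifluoromethyl)phenyl, would carry over to the 2,4,6-trimethylphenyl series. Also open, on these data alone, is how a ring bearing an amine or a carboxylic acid would read at this position.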